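The source may hold more compounds than are shown below. What is called first, only, known or untested is meant among the compounds shown, and "the series" means these compounds.

Measured so far in a functional assay on HepG2 cells (Homo sapiens) for cytotoxicity, with a stated time of 72 h; a higher number here means that more compound is needed for the effect, a lower number that less compound is needed:
- compound 1 `COc1ccc(/C=C/[C@@](C)(/C=C/c2ccc(O)c(/C=C/C#N)c2)CCC=C(C)C)cc1`: > 26000 nM (a limit)
- compound 2 `CCOC(=O)/C=C/c1cc(/C=C/[C@](C)(/C=C/c2ccc(OC)cc2)CCC=C(C)C)ccc1O`: > 52000 nM (a limit)

Compound 2 stands only as a limit, with no number behind it. Within the data shown here, the one other value, that of compound 1, is also a limit, so nothing places compound 2 more exactly.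

Compound 3 `COc1ccc(/C=C/[C@@](C)(/C=C/c2ccc(O)c(/C=C/C(=O)OCc3ccccc3)c2)CCC=C(C)C)cc1` is the next to consider. Its difference from compound 2 is phenyl in place of methyl on a saturated chain carbon bound to an oxygen next to a carbonyl group, which turns ethoxycarbonyl into benzyloxycarbonyl.

Among the measured compounds shown here, the only measured step bearing on this change is a step that the two limits leave unreadable from compound 1 to compound 2, where ethoxycarbonyl stands in place of cyano. That step gives neither a size nor a direction. No step beyond the scatter is therefore expected in this assay, and no direction can be set.

The expected step is an at least 1.3-fold lower number from compound 2 to compound 3 (0.11 log units; that floor lies within the scatter). The expectation rests on compound 2 with its limit of > 52000 nM, and a report of a limit is also expected for compound 3. The estimated value for compound 3 is 40000 nM, with an expected range of 15000 nM to 80000 nM.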

Compound 3, half-maximal effective concentration: > 26000 nM
Compound 3 was reported as a limit; the forecaster's own chance of this, stated with the estimate: 75%; the middle value does not contradict the limit.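

In this assay compound 3 is reported only as a limit, > 26000 nM. Compound 1, compound 2 and compound 3 all stand as limits, so the steps among them cannot be read. The compounds shown leave open whether cyano, ethoxycarbonyl and benzyloxycarbonyl differ at all in this assay, and at what concentration any of the three would reach the half-maximal effect.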